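A few compounds are considered here, and "the series" means these few. Any claim that something is new, unique, unknown or untested is made for them only; others in the source may bear on it.

Compounds measured so far:
compound 1 `CC1CCN(C2CCN(S(=O)(=O)c3cccnc3Cl)CC2)CC1` — > 5000 nM
compound 2 `Cc1cc(C)c(S(=O)(=O)N2CCN(C3CCN(C)CC3)CC2)c(C)c1` — 426 nM
compound 3 `CC1CCN(C2CCN(S(=O)(=O)c3cccc4cnccc34)CC2)CC1` — 225 nM

In a functional assay on DLD-1 cells (Homo sapiens) for antiproliferative activity, read by CellTiter-Glo, with a stated time of 72 h (on this read-out higher numbers stand for weaker inhibition and lower numbers for stronger inhibition), compound 1 gives only a limit, > 5000 nM, so no number is known for it. It therefore sits at the limit of > 5000 nM in this assay, at which 1 of the 3 values shown sits, and the other two values stand well inside the measured range. Compound 2 gives 426 nM in this assay, and compound 3 gives 225 nM; these two values show the range that the shared core reaches with other aryl groups on the sulfonyl sulfur.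

Compound 4 `CC1CCN(C2CCN(S(=O)(=O)c3cn(C)cn3)CC2)CC1` has not been measured in this assay. It differs from compound 1 in one place: 1-methyl-1H-imidazol-4-yl in place of 2-chloropyridin-3-yl on a sulfonyl sulfur. No measured step between any two of these compounds is available, so the size of the change cannot be read from a neighbour. Because compound 1 gives only a limit, > 5000 nM, the step is expected to be undefined in size, and the estimate is that a step that the limit leaves unreadable from compound 1 to compound 4 lies near nothing beyond the scatter. Compound 4 is expected to give about 8000 nM, between 2000 nM and 30000 nM, with a real chance that this assay again reports only a limit.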

Compound 4, half-maximal inhibitory concentration: > 5000 nM
Compound 4: no number, only a limit; the forecaster's own chance of this, stated with the estimate: 60%; the middle value is on the limit's open side.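

In this assay, among the compounds shown here, compound 1 and compound 4 each give only a limit, so no step between them can be read: the limit of > 5000 nM in this assay, at which 2 of the 4 values shown sit. The compounds shown leave open how far 1-methyl-1H-imidazol-4-yl and 2-chloropyridin-3-yl on a sulfonyl sulfur actually differ on the shared core.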